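This account rests on a few compounds, and the source may have more. Where it says the series, first, only, none or still open, it means among the compounds named here.

Compound 1 `N#CCn1c2ccc([N+](=O)[O-])cc2c(=O)n1Cc1ccccc1` gives > 256000 nM in an ADME assay on L929 cells (Mus musculus) for cytotoxicity, read by resazurin assay, with a stated time of 48 h (on this read-out lower numbers stand for higher toxicity in this test and higher numbers for lower toxicity in this test), a limit of the assay.
Compound 2 `CCOC(=O)CCCn1c2ccc([N+](=O)[O-])cc2c(=O)n1Cc1ccccc1` gives 78100 nM in this assay.
Compound 3 `O=c1c2cc([N+](=O)[O-])ccc2n(CCCO)n1Cc1ccccc1` gives > 256000 nM in this assay, a limit of the assay.

Compound 2 is thus the only one of the three with a number; the other two sit at the limit of > 256000 nM in this assay, at which 2 of the 3 values shown sit. Compound 4 `CC(=O)n1c2ccc([N+](=O)[O-])cc2c(=O)n1Cc1ccccc1` differs from compound 2 by acetyl in place of 3-(ethoxycarbonyl)propyl on an aromatic nitrogen. Among the measured compounds shown here, two measured steps bear on this change: an at least 3.2-fold lower number from compound 1 to compound 2 (0.51 log units; beyond the scatter) and an at least 3.2-fold higher number from compound 2 to compound 3 (0.51 log units; beyond the scatter). Both show the ester chain of compound 2 going with the lowest number, so swapping it for acetyl is expected to move the number back up, a 2.3-fold higher number from compound 2 to compound 4 (0.36 log units; beyond the scatter). Compound 4 is therefore estimated at 180000 nM, between 60000 nM and 300000 nM, with a real chance that only a limit is reported.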

Compound 4, concentration lethal to 50% of the cells: > 256000 nM
Compound 4 gave a limit, no number; the forecaster's own chance of this, stated with the estimate: 50%; at least 1.4-fold (0.15 log units) between middle value and limit.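

In this assay, acetyl in place of 3-(ethoxycarbonyl)propyl on this aromatic nitrogen gives an at least 3.2-fold higher number from compound 2 to compound 4 (0.51 log units; beyond the scatter). Among the compounds shown here, a third, different group at this position thus stands apart from the ester chain of compound 2, which remains the only compound with a measured number. Compound 4 gives only a limit of the assay, so its steps to compound 1 and compound 3 cannot be read: the limit of > 256000 nM in this assay, at which 3 of the 4 values shown sit.

Going by these compounds, how compound 1, compound 3 and compound 4 rank against one another stays open. Also open, on these data alone, is whether a carboxylic acid, an amine or a longer chain here would give a number like that of compound 2.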